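The source may hold more compounds than are shown below. What is called first, only, known or untested is meant among the compounds shown, and "the series" means these compounds.

Compound 2 `O=C(O)c1ccc(Cl)cc1-c1ccc2c(c1)OC[C@H](Cc1ccc(C(F)(F)F)cc1)[C@H]2O` belongs to the same series as compound 1 `O=C(O)c1ccc(Cl)cc1-c1ccc2c(c1)OC[C@H](Cc1ccccc1)[C@H]2O`. In a functional assay with leukotriene B4 receptor (Homo sapiens) as the target (on this read-out higher numbers stand for weaker inhibition and lower numbers for stronger inhibition), compound 1 gives 83 nM; 30 nM; 26 nM (3 entries), as the repeated entries the several entries of compound 1 in this assay, 83 nM; 30 nM; 26 nM (3 entries) show. In this assay compound 2 gives 9000 nM, the only number shown for it, beside one further entry that carries no single number. On that number compound 2 stands far from compound 1.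

Compound 3 `O=C(O)c1ccc(Cl)cc1-c1ccc2c(c1)OC[C@H](Cc1ccc3ccccc3c1)[C@H]2O` differs from compound 2 in one place: naphthalen-2-yl in place of 4-(trifluoromethyl)phenyl on a saturated chain carbon bound to a saturated ring carbon. Among the compounds with values here, no step between two measured compounds covers this exchange, so the account can lean only on the two values shown. Compound 1 gives 83 nM; 30 nM; 26 nM (3 entries), and compound 2 gives 9000 nM. The step that the estimate means, a 6.0-fold lower number from compound 2 to compound 3 (0.78 log units; beyond the scatter), is expected to run toward lower numbers, beyond the usual scatter, yet with wide uncertainty, since neither value settles how naphthalen-2-yl will fare on this read-out. Compound 3 is expected to give 1500 nM, with a range from 200 nM to 12000 nM.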

Compound 3, half-maximal inhibitory concentration: 2250 nM
Compound 3: middle estimate off by 1.5-fold (0.18 log units), on the low side; the measured number falls inside the stated range.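

In this assay, exchanging 4-(trifluoromethyl)phenyl for naphthalen-2-yl on a saturated chain carbon bound to a saturated ring carbon gives a 4.0-fold lower number from compound 2 to compound 3 (0.60 log units; beyond the scatter). Both groups hold 10 heavy atoms and neither carries a hydrogen-bond donor or acceptor, so the number at this place depends on which group sits there, even when these counts stay the same. Yet compound 3, at 2250 nM, still stands well above compound 1, so the exchange closes only part of the distance between compound 2 and compound 1, whose repeated entries serve as the reference: the several entries of compound 1 in this assay, 83 nM; 30 nM; 26 nM (3 entries)

The compounds shown do not tell why naphthalen-2-yl gives a lower number than 4-(trifluoromethyl)phenyl, and with only these two groups set against compound 1, no trend at this place can be drawn. On these data alone, it remains open what a 4-methoxyphenyl or a pyridin-3-yl group would give here, and whether any group at this place can match compound 1.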